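The compounds below may be only part of what the source reports. "The series", "measured", "known", "first", "only" and "open" are said of these compounds alone.

Of the compounds shown here, two have so far been measured in an assay on HEK293 cells for positive allosteric modulation of metabotropic glutamate receptor 2 (Rattus norvegicus), read by thallium flux, with a stated time of 2.5 min; a lower number here means that less compound is needed, a higher number that more compound is needed for the effect. Compound 1 `Cc1c(OCCCCOCOc2ccc(C(=O)O)cc2)ccc(C(=O)CC2CCCC2)c1O` gives 228 nM there. Compound 2 `Cc1c(OCCCCOc2ccc(F)c(C(=O)O)c2)ccc(C(=O)CC(C)C)c1O` gives 153 nM in this assay, the lowest of the two numbers, though its nearest neighbour, compound 1, lies within the usual scatter of repeated measurements, so no order can be read between the two. Compound 3 `Cc1c(OCCCCOc2ccc(F)c(C(=O)O)c2)ccc(C(=O)CC2CCCC2)c1O` has not been measured; it differs from compound 2 in one place: cyclopentyl in place of isopropyl on a saturated chain carbon bound to a carbonyl carbon. Within the data shown here, compound 1 carries the same cyclopentyl group, but compound 1 and compound 2 also differ elsewhere, so no single step connects them and the weight of this change cannot be read from their two values. The expectation for compound 3 therefore rests on compound 2 alone. Compound 3 is estimated to give 170 nM in this assay, within a range from 70 nM to 420 nM. The step of a 1.1-fold higher number from compound 2 to compound 3 (0.05 log units; within the scatter) implied by this estimate is expected to stay within the scatter, in no settled direction.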

Compound 3, half-maximal effective concentration: 699 nM
Compound 3: the middle estimate sits 4.1-fold (0.61 log units) below what was measured, outside the stated range (above it).
By their numbers in this assay, from the lowest: compounds 2 and 1 (each within the scatter of the next); then compound 3.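

At the saturated chain carbon bound to a carbonyl carbon, the choice of group proved not to be neutral: cyclopentyl in place of isopropyl gives a 4.6-fold higher number from compound 2 to compound 3 (0.66 log units; beyond the scatter), a step beyond the scatter. With cyclopentyl held fixed, the other end of the molecule also counts: 3-carboxy-4-fluorophenyl in place of (4-carboxyphenoxy)methyl on an oxygen on a saturated carbon gives a 3.1-fold higher number from compound 1 to compound 3 (0.49 log units; beyond the scatter), so the cyclopentyl group does not set the number alone. Nothing available gives a reason for either step.

Going by these compounds, whether the ring or the added carbons carry the first step stays open, and a cyclobutyl group, a tert-butyl group or a longer open chain at this place would help separate the two. On these data alone, it is also open whether isopropyl in place of cyclopentyl would have the same weight with the (4-carboxyphenoxy)methyl end in place.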